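From chloro to nitro at the limit of the read-out

The source may report more compounds than this note shows. Statements on the series, on what has been measured and on what is new or still open speak of the compounds shown alone.

Values so far in an ADME assay on BJ cells (Homo sapiens) for cytotoxicity, with a stated time of 72 h (on this read-out higher numbers stand for an effect only at larger amounts of compound and lower numbers for an effect already at smaller amounts), for the compounds:
Compound 1 `Cc1nn(-c2ccccc2)c2nc(-c3ccccc3)c(C#N)c(-c3ccccc3O)c12` gives > 23000 nM
Compound 2 `Cc1nn(-c2ccccc2)c2nc(-c3ccc(Cl)cc3)c(C#N)c(-c3ccccc3O)c12` gives > 20000 nM
Compound 3 `Cc1nn(-c2ccccc2)c2nc(-c3ccc([N+](=O)[O-])cc3)c(C#N)c(-c3ccccc3O)c12` has no value yet

Compound 2 stands at > 20000 nM in this assay, and that entry is a limit, not a number. Compound 1 stands at > 23000 nM in the same read-out, and that entry is also a limit.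

The move to compound 3 is described by nitro in place of chloro on an aromatic carbon, in words nitro in place of chloro on an aromatic carbon, so that 4-chlorophenyl becomes 4-nitrophenyl. Among the compounds with values here, one measured step bears on this: a step that the two limits leave unreadable from compound 1 to compound 2, chloro in place of hydrogen on an aromatic carbon. That step gives no size to carry over, so no step beyond the scatter is expected in this assay, though this rests on very little.

The estimated step is a step that the limit leaves unreadable from compound 2 to compound 3, and it is only an expectation. For compound 3 the estimate is 22000 nM, with an expected range from 9000 nM to 50000 nM, and the assay may well report only a limit again.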

Compound 3, half-maximal effective concentration: > 20000 nM
Compound 3 gave a limit, no number; the forecaster's own chance of this, stated with the estimate: 75%; the middle value does not contradict the limit.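

In this assay, compound 1, compound 2 and compound 3 all give limits rather than numbers, and no step among these three compounds can be read. The compounds shown leave open where any of the three would begin to show an effect on these cells, and whether 4-chlorophenyl and 4-nitrophenyl differ at all.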